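This account rests on a few compounds, and the source may have more. Where it says the series, first, only, none or still open, it means among the compounds named here.

Compound 1, `C(=C/c1ncnc2c1ncn2C1CCOCC1)\c1ccccc1`: 66%
Compound 2, `Nc1nc(/C=C/c2ccccc2)c2ncn(Cc3ccccc3)c2n1`: 91%
Compound 3, `C(=C/c1[nH]cnc2ncnc1-2)\c1ccsc1`: 32%

In a functional assay on K562 cells (Homo sapiens) for inhibition, read by thymidine incorporation, with a stated time of 48 h, tested at 10 ug/mL (on this read-out lower numbers stand for less inhibition and higher numbers for more inhibition at the one concentration tested (going by the name of the read-out)), compound 1 stands second highest of these three numbers. Compound 2 lies higher by a gap beyond the usual scatter, and compound 3 lies lower by a gap that is also beyond it. The unmeasured compound 4, `C/C(=C\C=C\c1ncnc2c1ncn2C1CCOCC1)CO`, is reached from compound 1 by a single change: 2-(hydroxymethyl)prop-1-en-1-yl in place of phenyl on a double-bonded chain carbon bound to a double-bonded chain carbon. Going by the values given here, no measured pair shows a swap of this kind, so its effect can only be judged from the spread of the three numbers and the nature of the change. A moderate drop in this assay is expected. The estimated step is a number 21 percentage points lower from compound 1 to compound 4 (beyond the scatter). Compound 4 is therefore expected to give about 45%, with a likely range from 20% to 70%.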

Compound 4, a percentage reported as inhibition, at one concentration (the size of the read-out at that concentration, not a potency): 27%
Compound 4: middle estimate off by 18 percentage points, on the high side; measured number inside the range.
By their numbers in this assay, from the lowest: compounds 4 and 3 (each within the scatter of the next); then compound 1; then compound 2.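

In this assay, putting 2-(hydroxymethyl)prop-1-en-1-yl in place of phenyl on a double-bonded chain carbon bound to a double-bonded chain carbon gives a number 39 percentage points lower from compound 1 to compound 4 (beyond the scatter). Going by these compounds alone, this is the first direct comparison at this position, and it shows that the group held there can change the read-out substantially. Nothing shown here explains the drop.

As far as these compounds go, the swap removes an aromatic ring and adds a hydroxyl group together, so their separate contributions remain open. A pyridine ring or a plain butyl chain at this position could help tell them apart.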